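Methyl for hydrogen on a weak antiproliferative dichloroacetamide

The source may hold more compounds than are shown below. What is called first, only, known or untested is meant among the compounds shown, and "the series" means these compounds.

For the measured compounds named here, compound 1 `O=C(Nc1ccccc1)C(Cl)Cl` is the only member of this small set with a number to show. In a functional assay on A549 cells (Homo sapiens) for antiproliferative activity, read by MTT assay, with a stated time of 72 h (a higher number here means a weaker inhibitor, a lower number a stronger inhibitor), compound 1 gives 130000 nM, which places it firmly among weak inhibitors; it is neither strongest nor weakest by comparison, since no other result stands beside it. Compound 2 `COC(=O)c1cccc(NC(=O)C(Cl)Cl)c1` carries a methyl ester on the aromatic ring of carbon only, and in this assay compound 2 is reported as "not determined" (no result reported). Compound 3 `O=C(Nc1cccc(OC(=O)C(Cl)Cl)c1)C(Cl)Cl` bears a second dichloroacetyl group as an ester, and in this assay compound 3 is likewise reported as "not determined" (no result reported). Neither of these two therefore offers a step against which compound 1 can be judged.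

Compound 4 `Cc1ccc(NC(=O)C(Cl)Cl)cc1` differs from compound 1 by a single change: methyl in place of hydrogen on an aromatic carbon, para to a group of 6 heavy atoms. Going by the values given here, no measured pair in the set shows what such a change does here, so the expectation rests only on the small size of the addition. The step of a 1.2-fold lower number from compound 1 to compound 4 (0.07 log units; within the scatter) is expected to stay within the usual scatter, with no clear direction. Compound 4 is accordingly estimated at 110000 nM in this assay, with a range from 40000 nM to 300000 nM.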

Compound 4, half-maximal inhibitory concentration: 48900 nM
The estimate for compound 4 lay 2.2-fold (0.35 log units) above the measured number; low and high end bracket the measured number.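

Methyl in place of hydrogen on an aromatic carbon, para to a group of 6 heavy atoms, gives the first step that can be read in this set: in this assay the change brings a 2.7-fold lower number from compound 1 to compound 4 (0.42 log units; beyond the scatter), a modest move that lies beyond the usual scatter. Compound 2 and compound 3 have no result and could show nothing of the kind, whereas this step shows that the position accepts a methyl without loss and that so small an addition can shift the number towards a stronger inhibitor. Nothing measured here explains why the number falls, so the step stands as an observation only.

One step at one place cannot tell whether the gain is particular to methyl or would also appear with an ethyl group, a methoxy group, a chlorine atom or an amine on the same carbon. The compounds shown also leave open whether methyl on a different aromatic carbon would move the number at all, and whether the step would hold with a change in the dichloroacetyl part.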